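Cytotoxicity Outlook for a Dichlorophenylsulfanyl Analogue

This account rests on a few compounds, and the source may have more. Where it says the series, first, only, none or still open, it means among the compounds named here.

Compound 1, `CCC1=C(C(=O)OCC2CCCCC2)C(c2cccc(O)c2)NC(=O)N1`: in an ADME assay on cells (Homo sapiens) for cytotoxicity, read by resazurin assay, with a stated time of 5 days (a lower number here means that less compound is tolerated, a higher number that more compound is tolerated), compound 1 gives > 10000 nM, which is a limit of the assay rather than a number.
Compound 2, `COc1ccc(-c2nc(COc3cccc(Cl)c3)nc3ccsc23)cn1`: in this assay compound 2 gives > 50000 nM, again a limit.
Compound 3, `O=S(=O)(Cc1nc(-c2ccncc2)c2sccc2n1)c1cccc(Cl)c1`: in this assay compound 3 gives > 50000 nM, also a limit.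

Compound 2 therefore stands at the limit of > 50000 nM in this assay, at which 2 of the 3 values shown sit, and compound 1 stands at the limit of > 10000 nM in this assay, at which 1 of the 3 values shown sits. Going by the values given here, none of the three values is a number, and no two measured compounds differ in only one place, so no measured step can be sized here.

Compound 4, `COc1ccc(-c2nc(CSc3cc(Cl)ccc3Cl)nc3ccsc23)cn1`, differs from compound 2 by (2,5-dichlorophenyl)sulfanyl in place of 3-chlorophenoxy on a saturated chain carbon bound to an aromatic carbon.

With every measured value sitting at a limit, the step in this assay is expected to be a number no higher from compound 2 to compound 4 (the limit leaves the size open), which is no change beyond the usual scatter. Compound 4 is expected to give 50000 nM, with a range from 20000 nM to 100000 nM, and most likely the assay will again report only a limit.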

Compound 4, half-maximal cytotoxic concentration: > 50000 nM
Compound 4: a limit, no number; the forecaster's own chance of this, stated with the estimate: 75%; the middle value sits exactly at the limit.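

In this assay compound 2 and compound 4 each give only a limit, not a number, and the step between them cannot be read. The compounds shown leave open at what concentration either one harms cells, and whether (2,5-dichlorophenyl)sulfanyl in place of 3-chlorophenoxy changes that concentration at all.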